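Swapping trifluoromethyl for methoxy on the aryl oxadiazole

A few compounds are considered here, and "the series" means these few. Any claim that something is new, unique, unknown or untested is made for them only; others in the source may bear on it.

Of the compounds shown here, three sharing one core have been tested in an assay on HL-60 cells for inhibition of glutathione S-transferase P (Homo sapiens); a higher number here means a weaker inhibitor, a lower number a stronger inhibitor. Compound 1 `C=C(CC)C(=O)c1ccc(OCc2nc(C)no2)c(Cl)c1Cl` gives 4000 nM. Compound 2 `C=C(CC)C(=O)c1ccc(OCc2nc(-c3ccccc3)no2)c(Cl)c1Cl` gives 3600 nM, a change of a 1.1-fold lower number from compound 1 to compound 2 (0.05 log units; within the scatter). Compound 3 `C=C(CC)C(=O)c1ccc(OCc2nc(-c3ccc(C(F)(F)F)cc3)no2)c(Cl)c1Cl` reaches only a limit of the assay, > 40000 nM. It stands at the weak end of the three, with an at least 11-fold higher number from compound 2 to compound 3 (1.04 log units; beyond the scatter) and an at least 10-fold higher number from compound 1 to compound 3 (1.00 log units; beyond the scatter), both resting on (the limit of > 40000 nM in this assay, at which 1 of the 3 values shown sits). Compound 4 `C=C(CC)C(=O)c1ccc(OCc2nc(-c3ccc(OC)cc3)no2)c(Cl)c1Cl` differs from compound 3 by methoxy in place of trifluoromethyl on an aromatic carbon. Among the measured compounds shown here, no measured step makes this exact exchange; the closest evidence is an at least 11-fold higher number from compound 2 to compound 3 (1.04 log units; beyond the scatter), where the arrival of trifluoromethyl pushed the number far up, and its departure is expected to undo much of that, an at least 5.7-fold lower number from compound 3 to compound 4 (0.75 log units; beyond the scatter). For compound 4 the estimate is 7000 nM, within 2500 nM to 40000 nM.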

Compound 4, half-maximal inhibitory concentration: 3800 nM
Beside the measured number, compound 4's estimate is 1.8-fold (0.27 log units) above it, within the range that was stated.
By their numbers in this assay, from the lowest: compounds 2, 4 and 1 (each within the scatter of the next). At a limit, above all of these: compound 3.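

In this assay, a substituent at this position of the phenyl is not in itself enough to lose activity, since exchanging trifluoromethyl for methoxy gives an at least 10-fold lower number from compound 3 to compound 4 (1.02 log units; beyond the scatter). Methoxy keeps the number level with the unsubstituted phenyl, a 1.1-fold higher number from compound 2 to compound 4 (0.02 log units; within the scatter), and with the methyl group, a 1.1-fold lower number from compound 1 to compound 4 (0.02 log units; within the scatter). The first of these steps rests on a limit of the assay for compound 3: the limit of > 40000 nM in this assay, at which 1 of the 4 values shown sits.

Going by these compounds, how far compound 3 truly lies from the others remains open. So does whether an amine or a carboxylic acid at this position would behave like methoxy or like trifluoromethyl.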